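A few compounds are considered here, and "the series" means these few. Any claim that something is new, unique, unknown or untested is made for them only; others in the source may bear on it.

Notes on the series in a functional assay on the whole organism (artery, strain albino) with Rattus norvegicus as the target, with a stated time of 900 min, at a dose of 10 mg/kg by the oral route; on this read-out lower numbers stand for less inhibition and higher numbers for more inhibition at the one dose given (going by the name of the read-out).

Compound 1 `CC1=C(C(=O)Nc2ccc(F)cc2)C(c2ccc([N+](=O)[O-])cc2)N=C(SCc2cccc(Cl)c2)N1` gives 10.8%. Compound 2 `CC1=C(C(=O)Nc2ccc(F)cc2)C(c2ccc([N+](=O)[O-])cc2)N=C(SCc2ccc(Cl)cc2)N1` carries the change 4-chlorophenyl in place of 3-chlorophenyl on a saturated chain carbon bound to a sulfur and gives 16.9%; the step is a number 6.1 percentage points higher from compound 1 to compound 2 (within the scatter). Compound 3 `CC1=C(C(=O)Nc2ccc(Br)cc2)C(c2ccc(Cl)cc2Cl)N=C(SCc2cccc(Cl)c2)N1` gives 7.2%; the difference between the core of compound 3 and the core of compound 1 is not broken down here, and the two values sit within the scatter of each other.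

Compound 4 `CC1=C(C(=O)Nc2ccc(Br)cc2)C(c2ccc(Cl)cc2Cl)N=C(SCc2ccc(Cl)cc2)N1` is not yet measured. It differs from compound 3 by 4-chlorophenyl in place of 3-chlorophenyl on a saturated chain carbon bound to a sulfur, the same change as from compound 1 to compound 2, at the same place. Because the earlier step of a number 6.1 percentage points higher from compound 1 to compound 2 (within the scatter) stayed within the scatter, the step from compound 3 to compound 4 is expected to be of similar size, a number 4.8 percentage points higher from compound 3 to compound 4 (within the scatter). For compound 4 the value in this assay is estimated at 12%, with a likely range from 0% to 25%.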

Compound 4, a percentage reported as inhibition, in the whole organism at one dose (the size of the read-out at that dose, not a potency): 22.1%
The estimate for compound 4 lay 10.1 percentage points below the measured number, within the range that was stated.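

In this assay, 4-chlorophenyl in place of 3-chlorophenyl on a saturated chain carbon bound to a sulfur reads as a number 14.9 percentage points higher from compound 3 to compound 4 (beyond the scatter). The step points the same way on both cores, and the two steps cannot be told apart: the same change on two cores in this assay, a number 6.1 percentage points higher (within the scatter) from compound 1 to compound 2 and a number 14.9 percentage points higher (beyond the scatter) from compound 3 to compound 4, 8.8 percentage points apart, within the scatter of two such steps. Going by these compounds alone, this does not establish a step of fixed size: only the step on the core of compound 3 stands clear of the scatter on its own, and two cores say nothing about any other core.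

Open, from the compounds shown here alone, is how an unsubstituted phenyl, a 4-methoxyphenyl or a longer chain at this place would read in this assay. The separate parts in which the core of compound 1 and the core of compound 3 differ also remain unresolved.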